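Carboxylic acid chain length across two aryl cores

A few compounds are considered here, and "the series" means these few. Any claim that something is new, unique, unknown or untested is made for them only; others in the source may bear on it.

Measured so far:
compound 1, `O=C(O)CCCCCCCCn1nc(-c2ccccc2)c(-c2ccccc2)c1-c1ccccc1`: 400 nM
compound 2, `O=C(O)CCCCCCCCCn1nc(-c2ccccc2)c(-c2ccccc2)c1-c1ccccc1`: 5500 nM
compound 3, `O=C(O)CCCCCCn1cc(-c2ccccc2)c(-c2ccccc2)n1`: a limit only, > 92000 nM

In a functional assay for inhibition, with Homo sapiens as the target (on this read-out lower numbers stand for stronger inhibition and higher numbers for weaker inhibition), compound 1 gives 400 nM and compound 2 gives 5500 nM. The change between them is carboxymethyl in place of carboxy on a saturated chain carbon, eight bonds along the chain from an aromatic nitrogen; the step is a 14-fold higher number from compound 1 to compound 2 (1.14 log units; beyond the scatter). For compound 3 this assay reports only a limit, > 92000 nM; it is the limit of > 92000 nM in this assay, at which 1 of the 3 values shown sits. How the core of compound 3 differs from the core of compound 1 is not broken down here.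

Compound 4, `O=C(O)CCCCCCCn1cc(-c2ccccc2)c(-c2ccccc2)n1`, has not been measured. It differs from compound 3 by carboxymethyl in place of carboxy on a saturated chain carbon, six bonds along the chain from an aromatic nitrogen. The place lines are not the same word for word: in compound 1 to compound 2 the chain carbon is eight bonds along the chain from an aromatic nitrogen, in compound 3 to compound 4 six bonds, so this is the same kind of change, not the same change.

Given that compound 3 already sits at a limit, and that the step from compound 1 to compound 2 went toward weaker inhibition, compound 4 is expected to remain at or beyond the limit, with an estimated step that the limit leaves unreadable from compound 3 to compound 4. The expected value for compound 4 is 200000 nM, estimated to lie between 60000 nM and 800000 nM.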

Compound 4, half-maximal inhibitory concentration: > 85000 nM
Compound 4 ended at the assay's limit; the forecaster's own chance of this, stated with the estimate: 80%; the middle value lies beyond the limit too.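

In this assay, compound 3 and compound 4 both stand only as limits, and the step between them cannot be read. Open, as far as these compounds go, is whether carboxymethyl in place of carboxy changes inhibition at all on the core of compound 3, and how that core compares with the core of compound 1 at a matched chain.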